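The source may report more compounds than this note shows. Statements on the series, on what has been measured and on what is new or still open speak of the compounds shown alone.

- compound 1 (`O=C(Nc1nn(C(=O)c2ccccc2)c2c1CN(C(=O)c1ccccc1)C2)c1ccccc1`): 1400 nM
- compound 2 (`O=C(Nc1nn(C(=O)C2CC2)c2c1CN(C(=O)c1ccccc1)C2)c1ccc(F)cc1`): 2280 nM
- compound 3 (`CC(=O)n1nc(NC(=O)c2ccccc2)c2c1CN(C(=O)C1CCC(C)CC1)C2`): 12200 nM

All three numbers come from a functional assay on HCT-116 cells (Homo sapiens) for cytotoxicity, read by sulforhodamine B assay, with a stated time of 48 h (on this read-out higher numbers stand for weaker inhibition and lower numbers for stronger inhibition), and compound 3 stands highest at 12200 nM with both gaps beyond the scatter. Compound 4 (`CC(=O)n1nc(NC(=O)c2ccccc2)c2c1CN(C(=O)c1ccncc1)C2`) carries pyridin-4-yl in place of 4-methylcyclohexyl on a carbonyl carbon. Among the compounds with values here, no measured pair differs in one place only. Compound 1 (1400 nM) and compound 2 (2280 nM) hold an aromatic ring on that carbonyl carbon, yet they also differ from compound 3 elsewhere, which makes them weak guides. The expected step of a 2.4-fold lower number from compound 3 to compound 4 (0.39 log units; beyond the scatter) is moderate and points toward stronger inhibition in this assay but may not clear the scatter by much. Compound 4 is estimated at 5000 nM (expected range 1800 nM to 14000 nM).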

Compound 4, half-maximal inhibitory concentration: 10000 nM
The estimate for compound 4 lay 2.0-fold (0.30 log units) below the measured number; the measured number falls inside the stated range.
By their numbers in this assay, from the lowest: compounds 1 and 2 (each within the scatter of the next); then compounds 4 and 3 (each within the scatter of the next).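

In this assay, within the data shown here, the change from 4-methylcyclohexyl to pyridin-4-yl on the carbonyl carbon gives a 1.2-fold lower number from compound 3 to compound 4 (0.09 log units; within the scatter) and provides the first one-place comparison. At this position, the read-out does not separate a non-aromatic carbon ring from an aromatic ring carrying a hydrogen-bond acceptor. No supporting evidence bears on this result.

Going by these compounds, whether a longer alkyl chain or an amine on this carbonyl carbon would give a different number remains open. Among these compounds, the contribution of the other two substituted places also remains open, since no pair isolates either one.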